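A few compounds are considered here, and "the series" means these few. Any claim that something is new, unique, unknown or untested is made for them only; others in the source may bear on it.

Measured so far in an assay on a protein complex (Cavia porcellus) with sulfonylurea receptors; K-ATP channels (Homo sapiens) as the target; on this read-out lower numbers stand for stronger inhibition and higher numbers for weaker inhibition:

Compound 1, `CCC(C)N(C(C)CC)S(=O)(=O)c1ccc(NC(=O)C(C)(O)C(F)(F)F)cc1`, gives > 30000 nM, which is a limit of this assay and not a number.
Compound 2, `CCN(CC)S(=O)(=O)c1ccc(NC(=O)C(C)(O)C(F)(F)F)cc1`, gives 810 nM.
Compound 3, `CC(O)(C(=O)Nc1ccc(-c2nn[nH]n2)cc1)C(F)(F)F`, gives > 30000 nM, again a limit of this assay rather than a number.

Among the compounds with values here, compound 2 therefore stands as the only compound with a measured number; the other two sit at the limit of > 30000 nM in this assay, at which 2 of the 3 values shown sit. The unmeasured compound 4, `CN(C)S(=O)(=O)c1ccc(NC(=O)C(C)(O)C(F)(F)F)cc1`, differs from compound 2 in one place: dimethylamino in place of diethylamino on a sulfonyl sulfur. It shortens the two chains on the sulfonyl nitrogen once more, in the same direction as the change that separates compound 1 from compound 2.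

That earlier step is the one that bears most directly on compound 4: an at least 37-fold lower number from compound 1 to compound 2 (1.56 log units; beyond the scatter). The other measured step, an at least 37-fold higher number from compound 2 to compound 3 (1.56 log units; beyond the scatter), removes the sulfamoyl group altogether and so speaks only to how much the group as a whole matters, not to the size of the chains on it.

Since shortening the chains once gave a large gain, a further shortening is expected to leave the number about where compound 2 lies or to lower it somewhat; the estimated step is a 1.4-fold lower number from compound 2 to compound 4 (0.13 log units; within the scatter). Compound 4 is thus estimated at 600 nM in this assay, with a range from 150 nM to 3000 nM.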

Compound 4, half-maximal inhibitory concentration: 480 nM
The estimate for compound 4 lay 1.3-fold (0.10 log units) above the measured number; the measured number falls inside the stated range.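

In this assay, dimethylamino in place of diethylamino on a sulfonyl sulfur gives a 1.7-fold lower number from compound 2 to compound 4 (0.23 log units; within the scatter), so compound 2 and compound 4 cannot be told apart, and the large gain seen on leaving bis(sec-butyl)amino does not visibly continue with this further shortening. The sulfamoyl group with the shortest chains shown still stands far from both inactive ends of the series: dimethylamino in place of bis(sec-butyl)amino gives an at least 62-fold lower number from compound 1 to compound 4 (1.79 log units; beyond the scatter), and dimethylsulfamoyl in place of 2H-tetrazol-5-yl gives an at least 62-fold lower number from compound 3 to compound 4 (1.79 log units; beyond the scatter). Both of these steps start from a limit of the assay and not from a number, so they give only a minimum size: the limit of > 30000 nM in this assay, at which 2 of the 4 values shown sit.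

The compounds shown leave open where between diethylamino and bis(sec-butyl)amino the number begins to rise, which a dipropylamino group on the sulfonyl sulfur would help to place. They also leave open whether the chains are needed at all, which a plain amino group would test, and whether tying them together into a pyrrolidine ring would change the number.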